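The source may report more compounds than this note shows. Statements on the series, on what has been measured and on what is new or still open speak of the compounds shown alone.

Measured in an assay on isolated protein for displacement of a labelled ligand from thyroid hormone receptor alpha (Homo sapiens), read by fluorescence polarization; a higher number here means a weaker inhibitor, a lower number a stronger inhibitor:
compound 1 `CCCCCCc1ccc(C(=O)CCN2CCC(C(=O)OC)CC2)cc1` gives 6300 nM
compound 2 `CCCCCCc1ccc(C(=O)/C=C\C(=O)O)cc1` gives 19200 nM
compound 3 `C=CC(=O)c1ccc(CCC)cc1` gives > 100000 nM

Compound 3 stands apart from the other two: its value of > 100000 nM is a limit of the assay, not a number. This is the limit of > 100000 nM in this assay, at which 1 of the 3 values shown sits. Compound 1 and compound 2, each carrying a hexyl chain on the aromatic ring, return measurable values; compound 3, with a propyl chain and a vinyl ketone, does not. For the measured compounds named here, no single-change pair among the measured compounds exists, so no measured step is available.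

Compound 4 `C=CC(=O)c1ccc(CCCCCCCC)cc1` differs from compound 3 by pentyl in place of hydrogen on a saturated chain carbon, three bonds along the chain from an aromatic carbon; cut one bond further out, the change reads methyl to hexyl. Since compound 3 sits at the limit, the size of the step cannot be referenced to a measured pair. The expectation is a gain in this assay beyond the scatter, into the measurable range, with an estimated step of an at least 2.5-fold lower number from compound 3 to compound 4 (0.39 log units; beyond the scatter). Compound 4 is estimated at 40000 nM, within a range from 8000 nM to 150000 nM.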

Compound 4, half-maximal inhibitory concentration: 21400 nM
For compound 4 the middle estimate is 1.9-fold (0.27 log units) above the measured one, and the stated range covers the measured number.
By their numbers in this assay, from the lowest: compound 1; then compounds 2 and 4 (each within the scatter of the next). At a limit, above all of these: compound 3.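

On the vinyl ketone, pentyl in place of hydrogen on a saturated chain carbon, three bonds along the chain from an aromatic carbon, brings the series from the limit into the measurable range of this assay, with an at least 4.6-fold lower number from compound 3 to compound 4 (0.66 log units; beyond the scatter). For the compounds shown here, this is the first single-change pair, and it shows that a change at this chain position alone moves the read-out while the vinyl ketone stays in place. The value of compound 3 is a limit of the assay and not a number, so the true size of the step stays unknown: the limit of > 100000 nM in this assay, at which 1 of the 4 values shown sits.

From the compounds shown here alone, whether a longer chain, or an amine or a carboxylic acid at the chain end, lowers the number further remains open. Also open, going by these compounds, is whether the same chain change carries over to the groups that replace the vinyl ketone in compound 1 and compound 2.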